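Amide linker with shorter chain in the isothiocyanate series

The source may hold more compounds than are shown below. What is called first, only, known or untested is meant among the compounds shown, and "the series" means these compounds.

Among the compounds with values here, compound 1 `CN(C)C(=O)c1cc2cnc(Nc3ccc(S(=O)(=O)NCCCCN=C=S)cc3)nc2n1C1CCCC1` gives 29.9% in a functional assay on NCI-H1299 cells (Homo sapiens) for inhibition, read by CCK-8 assay, with a stated time of 72 h, tested at 1 uM (on this read-out lower numbers stand for a weaker effect and higher numbers for a stronger effect at the one concentration tested), the lowest of the two numbers so far; compound 2 `CN(C)C(=O)c1cc2cnc(Nc3ccc(S(=O)(=O)NCCCCCCCN=C=S)cc3)nc2n1C1CCCC1` gives 58.9% in this assay. Within the data shown here, the single measured step, a number 29 percentage points higher from compound 1 to compound 2 (beyond the scatter), went with a longer chain. Compound 3 `CN(C)C(=O)c1cc2cnc(Nc3ccc(C(=O)NCCCN=C=S)cc3)nc2n1C1CCCC1` differs from compound 1 as a group of 9 heavy atoms (5 carbon, 2 nitrogen, 1 oxygen, 1 sulfur; no ring) in place of a group of 11 heavy atoms (5 carbon, 2 nitrogen, 2 oxygen, 2 sulfur; no ring), on an aromatic carbon. Among the measured compounds shown here, this exchange of sulfonamide for amide, with a shorter chain, has no measured counterpart, and the one recorded step offers no support for a gain here. Compound 3 is therefore expected to give 25% (range 5% to 50%), an expected step of a number 4.9 percentage points lower from compound 1 to compound 3 (within the scatter).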

Compound 3, a percentage reported as inhibition, at one concentration (the size of the read-out at that concentration, not a potency): 65.1%
For compound 3 the middle estimate is 40.1 percentage points below the measured one, outside the stated range (above it).
By their numbers in this assay, from the lowest: compound 1; then compounds 2 and 3 (each within the scatter of the next).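

In this assay, replacing the sulfonamide chain with the amide chain, on an aromatic carbon para to a large group, goes with a number 35.2 percentage points higher from compound 1 to compound 3 (beyond the scatter). A rise in this series therefore does not depend on a longer chain, since this group has fewer heavy atoms than the one it replaces. Linker and chain length change together in this step, their separate shares cannot be read, and no supporting measurement bears on the result.

Open questions are how an amide with a longer chain would read here, and whether an amine in place of the isothiocyanate would keep the effect.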